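The source may report more compounds than this note shows. Statements on the series, on what has been measured and on what is new or still open speak of the compounds shown alone.

Measured compounds:
compound 1, `Cn1cc(SCC(=O)Nc2cccc(Cl)c2)c2ccccc21`: > 100000 nM in an ADME assay on HEK-293T cells (Homo sapiens) for cytotoxicity, read by CCK-8 assay, with a stated time of 48 h (a higher number here means that more compound is tolerated, a lower number that less compound is tolerated), a limit of the assay rather than a number.
compound 2, `Cn1cc(SCC(=O)Nc2cccc(Cl)c2Cl)c2ccccc21`: > 100000 nM, likewise a limit.
compound 3, `Cn1cc(SCC(=O)Nc2ccc(Cl)cc2)c2ccccc21`: > 100000 nM, again a limit.

The step from compound 1 to compound 2 is chloro in place of hydrogen on an aromatic carbon; its size is a step that the two limits leave unreadable from compound 1 to compound 2. The two cores differ as 4-chlorophenyl in place of 3-chlorophenyl on an amide-type nitrogen, giving a step that the two limits leave unreadable from compound 1 to compound 3. Compound 4, `Cn1cc(SCC(=O)Nc2ccc(Cl)cc2Cl)c2ccccc21`, carries the same kind of change as compound 2: chloro in place of hydrogen on an aromatic carbon. The surroundings are not identical: in compound 2 the entering chloro is ortho to a chloro group and ortho to a large group, whereas in compound 4 it is ortho to a large group and meta to a chloro group.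

Among the measured compounds shown here, what is known rests on (the limit of > 100000 nM in this assay, at which 3 of the 3 values shown sit); all three measured compounds sit at that limit, so no step has a readable size. For compound 4 the step is estimated as a step that the limit leaves unreadable from compound 3 to compound 4, set beside the unreadable earlier one. Compound 4 is expected to give 150000 nM in this assay, most likely reported once more as a limit, with the plausible range 50000 nM to 400000 nM.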

Compound 4, half-maximal cytotoxic concentration: > 100000 nM
Compound 4 ended at the assay's limit; the forecaster's own chance of this, stated with the estimate: 80%; the middle value is on the limit's open side.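

Compound 3 and compound 4 both stand at a limit, so the step between them, chloro in place of hydrogen on an aromatic carbon, cannot be read: the limit of > 100000 nM in this assay, at which 4 of the 4 values shown sit.

Left open is whether any change to the shared core would give a readable number rather than a limit in this assay.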